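Swapping nitro for methoxy in compound 1

The source may hold more compounds than are shown below. What is called first, only, known or untested is meant among the compounds shown, and "the series" means these compounds.

In a functional assay on HeLa cells (Homo sapiens) for antiproliferative activity, read by sulforhodamine B assay, with a stated time of 48 h (on this read-out higher numbers stand for weaker inhibition and lower numbers for stronger inhibition), compound 1 (`COc1cc(C(=O)/C=C\Nc2ccc(-c3nc4cc(OC)c(OC)c(OC)c4s3)cc2C)cc([N+](=O)[O-])c1OC`) gives 13100 nM and compound 2 (`COc1cc(C(=O)/C=C\Nc2ccc(-c3nc4cc(OC)c(OC)c(OC)c4s3)cc2)cc([N+](=O)[O-])c1OC`) gives 7800 nM. For the measured compounds named here, these are the only two numbers so far, and they lie within the scatter of each other, so compound 1 has no firm rank. The next entry is compound 3 (`COc1cc(C(=O)/C=C\Nc2ccc(-c3nc4cc(OC)c(OC)c(OC)c4s3)cc2C)cc(OC)c1OC`), with methoxy in place of nitro on an aromatic carbon. Going by the values given here, the only measured step, a 1.7-fold lower number from compound 1 to compound 2 (0.23 log units; within the scatter), is hydrogen in place of methyl on an aromatic carbon, a different change. Among the compounds with values here, it shows that this one small edit stayed within the scatter, but no measured pair covers the exchange of nitro for methoxy. Both measured compounds carry nitro, so the data give no direct guide to size or direction in this assay. A modest move towards a lower number is expected, as a judgement held with little confidence, and a result within the scatter would fit equally well. The estimated step is a 2.6-fold lower number from compound 1 to compound 3 (0.42 log units; beyond the scatter). Compound 3 is estimated at 5000 nM, with an expected range of 900 nM to 20000 nM.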

Compound 3, half-maximal inhibitory concentration: 11100 nM
Beside the measured number, compound 3's estimate is 2.2-fold (0.35 log units) below it; measured number inside the range.
By their numbers in this assay, from the lowest: compounds 2, 3 and 1 (each within the scatter of the next).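

In this assay, for the compounds shown here, methoxy in place of nitro on this aromatic carbon, ortho to a methoxy group and meta to a large group, gives a 1.2-fold lower number from compound 1 to compound 3 (0.07 log units; within the scatter), the first measured pair for this exchange. Compound 3 reads 11100 nM without the nitro group, so in this background nitro is not needed for a number of this order, and the two groups are not separated at this position despite their different counts of heavy atoms and hydrogen-bond acceptors. With a 1.7-fold lower number from compound 1 to compound 2 (0.23 log units; within the scatter) as well, neither single edit shown around compound 1 leaves the scatter, and no supporting measurement bears on the reason for this result.

The compounds shown leave open whether an amine, a carboxylic acid or a longer chain on this aromatic carbon would give a step beyond the scatter from compound 1. They also leave open whether methoxy in place of nitro would read the same way on compound 2, which carries hydrogen in place of the methyl.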